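This account rests on a few compounds, and the source may have more. Where it says the series, first, only, none or still open, it means among the compounds named here.

Compound 2, `CCCCCCCCCCCCCCCOC1(c2ccc(Cl)cc2)SC=C(C)n2c1noc2=O`, was tested in a functional assay on A2780/DX3 cells (Homo sapiens) for antiproliferative activity, read by MTT assay, with a stated time of 3 days; a higher number here means a weaker inhibitor, a lower number a stronger inhibitor. In this assay compound 2 gives only a limit, > 100000 nM, not a measured number. Compound 1, `CCCCCCCCCCCCCCCCCCOC1(c2ccc(Br)cc2)SC=C(C)n2c1noc2=O`, differs from it in its halogen and in the length of its chain. In this assay compound 1 likewise stops at a limit, > 100000 nM. Both results therefore sit at the same point: the limit of > 100000 nM in this assay, at which 2 of the 2 values shown sit.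

Compound 3, `CCCCCCCCCCCCCCCCCCOC1(c2ccc(Cl)cc2)SC=C(C)n2c1noc2=O`, differs from compound 2 by propyl in place of hydrogen on a saturated chain carbon, ten or more bonds along the chain from an oxygen on a saturated carbon. Within the data shown here, since no pair of measured compounds is joined by a single change, the numbers themselves give no size for such a step. Compound 1 already carries this longer chain and yet reaches only the limit, > 100000 nM. The expected step is thus a step that the limit leaves unreadable from compound 2 to compound 3, nothing beyond the usual scatter. Compound 3 is expected to give about 150000 nM, somewhere from 50000 nM to 500000 nM, most probably reported again only as a limit.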

Compound 3, half-maximal inhibitory concentration: > 100000 nM
Compound 3 was reported as a limit (the forecaster's own chance of this, stated with the estimate: 85%); the middle value is on the limit's open side.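

In this assay compound 3 gives only a limit, > 100000 nM. No step from compound 1 or compound 2 to compound 3 can be read: the limit of > 100000 nM in this assay, at which 3 of the 3 values shown sit.

The compounds shown leave open whether chloro in place of bromo, or propyl in place of hydrogen on the chain, changes activity at all in this assay.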